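A Second Benzyl Sulfide on a Weak Cell Inhibitor

The compounds below may be only part of what the source reports. "The series", "measured", "known", "first", "only" and "open" are said of these compounds alone.

Compound 1 `Cc1cc(N2CC[C@@H](C)[C@@H](N(C)c3ncnc4[nH]ccc34)C2)n2ncnc2n1` was tested in a functional assay on HGC-27 cells (Homo sapiens) for inhibition, read by MTT assay, with a stated time of 72 h (a lower number here means a stronger inhibitor, a higher number a weaker inhibitor), where compound 1 gives 11300 nM. Among the two numbers measured so far, this is the highest; the nearest is compound 2 `Cc1cc(N2CC[C@@H](C)[C@@H](N(C)c3ncnc4[nH]ccc34)C2)n2nc(SCc3ccc(C(F)(F)F)cc3)nc2n1`, which in this assay gives 9540 nM. That step, a 1.2-fold lower number from compound 1 to compound 2 (0.07 log units; within the scatter), came from putting (4-(trifluoromethyl)benzyl)sulfanyl in place of hydrogen on an aromatic carbon, and it did not leave the scatter.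

Compound 3 `COc1ccc(CSc2nc3nc(C)cc(N4CC[C@@H](C)[C@@H](N(C)c5ncnc6[nH]ccc56)C4)n3n2)cc1` has not yet been measured. It differs from compound 1 as follows: (4-methoxybenzyl)sulfanyl in place of hydrogen on an aromatic carbon. For the measured compounds named here, only the single step above bears on this change, since it also adds a benzyl sulfide at the same aromatic carbon, and that step stayed within the scatter. No step beyond the scatter is therefore expected in this assay in either direction.

Compound 3 is expected to give about 10000 nM, with a range from 4000 nM to 25000 nM. This amounts to an expected step of a 1.1-fold lower number from compound 1 to compound 3 (0.05 log units; within the scatter).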

Compound 3, half-maximal inhibitory concentration: 18200 nM
Compound 3: the middle estimate sits 1.8-fold (0.26 log units) below what was measured, within the range that was stated.
By their numbers in this assay, from the lowest: compounds 2, 1 and 3 (each within the scatter of the next).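

In this assay, a second benzyl sulfide on this aromatic carbon, the one between two ring nitrogen atoms, again leaves the number close to that of the parent with hydrogen there (a 1.6-fold higher number from compound 1 to compound 3 (0.21 log units; within the scatter)). For the compounds shown here, the result also gives the first reading of a change on the benzyl ring itself, methoxy in place of trifluoromethyl (a 1.9-fold higher number from compound 2 to compound 3 (0.28 log units; within the scatter)). Hydrogen and the two benzyl sulfides thus all lie within the scatter of one another, and no measured evidence here accounts for these numbers.

As far as these compounds go, it remains open whether a different kind of group on this carbon, such as an amine or a carboxylic acid, would move the number beyond the scatter. A plain alkyl chain on the sulfur, in place of the benzyl group, is equally untested by these three compounds.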